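A few compounds are considered here, and "the series" means these few. Any claim that something is new, unique, unknown or untested is made for them only; others in the source may bear on it.

Measured compounds:
compound 1, `S=c1oc(-c2ccc3c(c2)OCCO3)nn1CNc1ccccc1`: 5140 nM
compound 2, `Fc1ccccc1NCn1nc(-c2ccc3c(c2)OCCO3)oc1=S`: 6390 nM
compound 3, `Cc1ccccc1NCn1nc(-c2ccc3c(c2)OCCO3)oc1=S`: 3450 nM

These three share one core and differ only in the group on the phenyl ring attached through the amine. In a functional assay, with a stated time of 6 min (on this read-out higher numbers stand for weaker inhibition and lower numbers for stronger inhibition), compound 2 gives the highest of the three numbers, but its separation from the others is small: a 1.2-fold higher number from compound 1 to compound 2 (0.09 log units; within the scatter) and a 1.9-fold lower number from compound 2 to compound 3 (0.27 log units; within the scatter), both within the scatter, so no ranking among them can be claimed. The remaining step, a 1.5-fold lower number from compound 1 to compound 3 (0.17 log units; within the scatter), is also within the scatter.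

Compound 4, `COc1ccccc1NCn1nc(-c2ccc3c(c2)OCCO3)oc1=S`, has not been measured. It differs from compound 2 in one place: methoxy in place of fluoro on an aromatic carbon. The change sits on an aromatic carbon of a six-membered aromatic ring of carbon only, ortho to a large group. Among the measured compounds shown here, the steps that bear on it are the three changes at that same carbon, and each stayed within the scatter. On that basis no step beyond the scatter is expected in this assay for compound 4, perhaps a slightly lower number in line with the methyl case; the estimate is 4500 nM, from 1800 nM to 11000 nM, meaning a step of a 1.4-fold lower number from compound 2 to compound 4 (0.15 log units; within the scatter) that is expected to stay within the scatter.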

Compound 4, half-maximal inhibitory concentration: 6300 nM
For compound 4 the middle estimate is 1.4-fold (0.15 log units) below the measured one; the measured number falls inside the stated range.
By their numbers in this assay, from the lowest: compounds 3, 1, 4 and 2 (each within the scatter of the next).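

Methoxy puts an oxygen, counted as a hydrogen-bond acceptor, on this aromatic carbon, yet in this assay exchanging it for fluoro gives a 1.0-fold lower number from compound 2 to compound 4 (0.01 log units; within the scatter) and the other two comparisons, a 1.8-fold higher number from compound 3 to compound 4 (0.26 log units; within the scatter) and a 1.2-fold higher number from compound 1 to compound 4 (0.09 log units; within the scatter), also stay small. Hydrogen, fluoro, methyl and methoxy at this carbon therefore cannot be told apart on this read-out, so the tolerance seen among the earlier compounds now extends to a group with two heavy atoms and an acceptor. Nothing available here explains this lack of separation.

Still open, on these data alone, is whether any group at this carbon can move the number beyond the scatter, for example an amine, a carboxylic acid or a longer chain such as butoxy. The compounds shown also leave open whether the same substitutions would behave alike elsewhere on this ring.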